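Amide substituent swap on a pyrimidine-proline series

The compounds below may be only part of what the source reports. "The series", "measured", "known", "first", "only" and "open" are said of these compounds alone.

Three compounds have been run so far in an assay on isolated protein for inhibition of serine/threonine-protein kinase Chk2 (Homo sapiens), read by HTRF, tested at 10 uM; on this read-out lower numbers stand for less inhibition and higher numbers for more inhibition at the one concentration tested (going by the name of the read-out). Compound 1 `CN(CCCn1ccnc1)C(=O)[C@@H]1CCCN1c1nccc(Nc2ccccc2)n1` gives 5% in this assay. Compound 2 `Cc1cccc(Oc2ccnc(N3CCN(C(=O)c4c(C)noc4C)CC3)n2)c1` gives 3%, and compound 3 `Cc1cc(C(=O)N2CCN(c3ncnc4c3CN(Cc3ccccc3)CC4)CC2)c(C)n1C` gives 2%. Compound 1 thus holds the upper number of the three, but the gaps to compound 2 and to compound 3 both lie within the usual scatter, so the three readings cannot be told apart and none of the compounds shows inhibition that stands out from noise at the concentration tested. Going by the values given here, no pair of measured compounds differs in one place only, so no measured step is available to calibrate a change of substituent.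

Among the compounds with values here, compound 4 `CN(C)CC(C)(C)CNC(=O)[C@@H]1CCCN1c1nccc(Nc2ccccc2)n1` is the first single-point change to be tested. Relative to compound 1 it differs as follows: (2-((dimethylamino)methyl)-2-methylpropyl)amino in place of (3-(1H-imidazol-1-yl)propyl)(methyl)amino on a carbonyl carbon. The amide carbonyl, the saturated ring and the aminopyrimidine part of compound 1 are kept.

Within the data shown here, with compound 1 sitting at 5% and no measured step to lean on, the expectation is that compound 4 stays in the same flat region, with the step of no change at the digits printed from compound 1 to compound 4 (within the scatter) expected to be none beyond the scatter. Compound 4 is therefore estimated at 5%, within a range of -5% to 15%.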

Compound 4, a percentage reported as inhibition, at one concentration (the size of the read-out at that concentration, not a potency): 0%
Compound 4: middle estimate off by 5 percentage points, on the high side; the range from low to high includes it.
By their numbers in this assay, from the lowest: compounds 4, 3, 2 and 1 (each within the scatter of the next).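

In this assay, going by these compounds alone, replacing (3-(1H-imidazol-1-yl)propyl)(methyl)amino with (2-((dimethylamino)methyl)-2-methylpropyl)amino on the carbonyl carbon gives a number 5 percentage points lower from compound 1 to compound 4 (within the scatter), the first measured step at this position. The two readings cannot be told apart, so this exchange of an imidazole-bearing side chain for an open chain with no ring, which also carries a hydrogen-bond donor, produces no inhibition that stands clear of the scatter. No supporting data bear on this result, so the flat step stands as an observation without an explanation.

Still open, going by these compounds, is whether any other group on this carbonyl carbon, such as a chain ending in a carboxylic acid, a longer chain ending in a morpholine or a simple benzyl amine, can raise the reading beyond the scatter. Also open, on these data alone, is whether the low readings follow from the shared core of compound 1 and compound 4 rather than from the amide substituent, which a change in the phenylamino part, such as a chloro or methoxy group on the phenyl ring, could test.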